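The source may report more compounds than this note shows. Statements on the series, on what has been measured and on what is new or still open speak of the compounds shown alone.

Working notes on the series. Of the compounds shown here, three of the shared core have been measured in a functional assay on BGC-823 cells (Homo sapiens) for inhibition, read by MTT assay, with a stated time of 72 h; a higher number here means a weaker inhibitor, a lower number a stronger inhibitor. Compound 1 `Cc1cc(N2CC[C@@H](C)[C@@H](N(C)c3ncnc4[nH]ccc34)C2)n2nc(SCc3ccccc3)nc2n1` gives 14400 nM. Compound 2 `Cc1cc(N2CC[C@@H](C)[C@@H](N(C)c3ncnc4[nH]ccc34)C2)n2nc(SCc3ccc(Cl)cc3)nc2n1` gives 26300 nM; of the two plain numbers in the set, compound 2 has the higher one, with compound 1 nearest, and the step of a 1.8-fold higher number from compound 1 to compound 2 (0.26 log units; within the scatter) stays within the scatter. Compound 3 `Cc1cc(N2CC[C@@H](C)[C@@H](N(C)c3ncnc4[nH]ccc34)C2)n2nc(SCc3csc4ccc(Cl)cc34)nc2n1` reaches only the limit of the assay, > 100000 nM. Since one value in the set is a limit (the limit of > 100000 nM in this assay, at which 1 of the 3 values shown sits), the steps of an at least 6.9-fold higher number from compound 1 to compound 3 (0.84 log units; beyond the scatter) and an at least 3.8-fold higher number from compound 2 to compound 3 (0.58 log units; beyond the scatter) can be read only as lower bounds on the loss.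

Compound 4 `Cc1cc(N2CC[C@@H](C)[C@@H](N(C)c3ncnc4[nH]ccc34)C2)n2nc(SCC3CCCCC3)nc2n1` has not been measured. It differs from compound 2 at one place: cyclohexyl in place of 4-chlorophenyl on a saturated chain carbon bound to a sulfur. Among the compounds with values here, the only measured steps that touch the same saturated chain carbon bound to a sulfur, an at least 6.9-fold higher number from compound 1 to compound 3 (0.84 log units; beyond the scatter) and an at least 3.8-fold higher number from compound 2 to compound 3 (0.58 log units; beyond the scatter), both raise the number, but each swaps one aromatic group for another aromatic group; no measured pair brings in a non-aromatic ring, so these steps bear on the present change only loosely. The expectation for compound 4 is therefore a small rise or none beyond the scatter, a 1.1-fold higher number from compound 2 to compound 4 (0.06 log units; within the scatter). For compound 4 the estimate in this assay is 30000 nM, with a range from 10000 nM to 100000 nM.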

Compound 4, half-maximal inhibitory concentration: 16300 nM
Compound 4: middle estimate off by 1.8-fold (0.26 log units), on the high side, and the stated range covers the measured number.
By their numbers in this assay, from the lowest: compounds 1, 4 and 2 (each within the scatter of the next). At a limit, above all of these: compound 3.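

Within the data shown here, at this saturated chain carbon bound to a sulfur, a non-aromatic ring now appears for the first time, and in this assay cyclohexyl cannot be told apart from the aromatic rings: a 1.6-fold lower number from compound 2 to compound 4 (0.21 log units; within the scatter) and a 1.1-fold higher number from compound 1 to compound 4 (0.05 log units; within the scatter) are both read as lying within the scatter. Among compounds 1, 2 and 4, then, the six-membered ring can be aromatic or not, and can carry a chloro or not, with no step beyond the scatter, so an aromatic ring is not needed here for a number of this size. Only compound 3 stands apart, with an at least 6.1-fold lower number from compound 3 to compound 4 (0.78 log units; beyond the scatter), and this step is a lower bound, as the value of compound 3 is a limit: the limit of > 100000 nM in this assay, at which 1 of the 4 values shown sits.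

The compounds shown leave open whether a group of another kind at this place, such as an amine, a carboxylic acid or a hydroxyl, would move the number beyond the scatter in either direction. Also open, as far as these compounds go, is whether a longer chain between the sulfur and the ring, or a smaller ring such as cyclopentyl, would do so.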